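The source may hold more compounds than are shown below. What is called first, only, known or untested is meant among the compounds shown, and "the series" means these compounds.

Of the compounds shown here, two have been measured in an assay on cells for antagonist activity at transient receptor potential cation channel subfamily V member 1 (Homo sapiens), read by FLIPR and calcium flux, with a stated time of 6 min (a lower number here means a stronger inhibitor, a higher number a weaker inhibitor), so far. Compound 1 `CCCCCc1nc(C(C)(C)C)ccc1CNC(=O)C(C)c1ccc(NS(C)(=O)=O)c(F)c1` gives 1.9 nM in this assay. Compound 2 `CC(C(=O)NCc1ccc(C(C)(C)C)cc1N1CCN(c2ccccc2)CC1)c1ccc(NS(C)(=O)=O)c(F)c1` gives 0.8 nM in this assay, the lowest of the two numbers; compound 1 sits higher by a gap that lies beyond the usual scatter, so compound 2 counts as the stronger inhibitor of the pair.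

Compound 3 `CC(C(=O)NCc1ccc(C(C)(C)C)cc1SC1CCCCC1)c1ccc(NS(C)(=O)=O)c(F)c1` differs from compound 2 in one place: cyclohexylsulfanyl in place of 4-phenylpiperazin-1-yl on an aromatic carbon. Among the measured compounds shown here, no measured pair shows this exact change, so its effect can only be guessed. The group that enters is smaller than the one that leaves, and the rest of compound 2 is kept, so a modest rise in the number is expected, a step of a 3.1-fold higher number from compound 2 to compound 3 (0.49 log units; beyond the scatter) in this assay. On that basis compound 3 is expected to give about 2.5 nM in this assay, most likely between 0.8 nM and 8 nM.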

Compound 3, inhibition constant: 7.4 nM
Estimate against measurement, compound 3: 3.0-fold (0.47 log units) below; the range from low to high includes it.
By their numbers in this assay, from the lowest: compound 2; then compound 1; then compound 3.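

In this assay, the change from 4-phenylpiperazin-1-yl to cyclohexylsulfanyl brings a 9.3-fold higher number from compound 2 to compound 3 (0.97 log units; beyond the scatter), so what sits on this aromatic carbon, ortho to a large group, clearly affects the number. Compound 3 still gives 7.4 nM, which shows that inhibition survives here with a group that has one ring rather than two and sulfur in place of nitrogen. All these differences arrive in a single step, and no measured property of either group accounts for its size.

The compounds shown leave open whether the size of the group, its second ring or its linking atom matters most. A cyclohexyloxy group, a phenylsulfanyl group or a piperidin-1-yl group on the same carbon could begin to separate these features.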